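Notes on the benzylidene series: compound 3 to compound 4

A few compounds are considered here, and "the series" means these few. Any claim that something is new, unique, unknown or untested is made for them only; others in the source may bear on it.

Of the compounds shown here, three sharing one core have been measured in a functional assay on Jurkat cells (Homo sapiens) for antiproliferative activity, read by MTT assay; a higher number here means a weaker inhibitor, a lower number a stronger inhibitor. Compound 1 `COc1cc2c(cc1OC)C(=O)/C(=C/c1cccc(Cl)c1)CC2` gives 9000 nM. Compound 2 `COc1cc2c(cc1OC)C(=O)/C(=C/c1cccc([N+](=O)[O-])c1)CC2` gives 9000 nM. Compound 3 `COc1cc2c(cc1OC)C(=O)/C(=C/c1cccc(C)c1)CC2` gives 17000 nM, the highest of the three numbers, though its gap to compound 1 and to compound 2 is within the scatter, so no order among the three can be claimed.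

The steps between them are all small: no change at the digits printed from compound 1 to compound 2 (within the scatter); a 1.9-fold higher number from compound 1 to compound 3 (0.28 log units; within the scatter); a 1.9-fold higher number from compound 2 to compound 3 (0.28 log units; within the scatter). Each of these exchanges one substituent for another on the same aromatic carbon, and none moves the number beyond the scatter.

Compound 4 `COc1cc2c(cc1OC)C(=O)/C(=C/c1ccc(N)cc1)CC2` differs from compound 3 by 4-aminophenyl in place of 3-methylphenyl on a double-bonded chain carbon bound to a double-bonded ring carbon. This change is of a different kind from the three measured steps: it exchanges the whole phenyl group, bringing in a hydrogen-bond donor and acceptor where the measured compounds carry none. For the measured compounds named here, no measured step bears on it directly; the only guidance is that every substituent exchange so far, including a 1.9-fold higher number from compound 2 to compound 3 (0.28 log units; within the scatter), stayed within the scatter.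

On that basis no step beyond the scatter is expected, with wide uncertainty. For compound 4 the expected value in this assay is 12000 nM, estimated between 3000 nM and 45000 nM. The expected step is a 1.4-fold lower number from compound 3 to compound 4 (0.15 log units; within the scatter).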

Compound 4, half-maximal inhibitory concentration: 40000 nM
Compound 4: the middle estimate sits 3.3-fold (0.52 log units) below what was measured; measured number inside the range.
By their numbers in this assay, from the lowest: compounds 1, 2 and 3 (each within the scatter of the next); then compound 4.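

In this assay, for the compounds shown here, 4-aminophenyl in place of 3-methylphenyl is the first exchange to move the number beyond the scatter, with a 2.4-fold higher number from compound 3 to compound 4 (0.37 log units; beyond the scatter) and, for 4-aminophenyl in place of 3-chlorophenyl, a 4.4-fold higher number from compound 1 to compound 4 (0.65 log units; beyond the scatter), both modest in size. The earlier exchanges among chloro, nitro and methyl on one aromatic carbon showed no sensitivity at all, whereas this place, on a double-bonded chain carbon bound to a double-bonded ring carbon, now shows that the number can respond to the group carried there, and in the direction of a weaker inhibitor. No measurement at hand bears on what lies behind this step.

The compounds shown leave open whether the step belongs to the amine itself or to the whole exchange of 3-methylphenyl for 4-aminophenyl, since the substituent and its place on the phenyl ring differ together. Also open, going by these compounds, is how a hydroxyl, a carboxylic acid or an acetamide in place of the amine would read in this assay, and whether any group here gives a lower number than the rest of the series.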